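A few compounds are considered here, and "the series" means these few. Any claim that something is new, unique, unknown or untested is made for them only; others in the source may bear on it.

The series shares one core, seen in compound 1 `O=C1O/C(=C\Cn2cnc3c(Cl)c(F)nc(F)c32)C(OCc2ccccc2)=C1OCc1ccccc1`, whose entry in a functional assay on L1210/0 cells (Mus musculus) for antiproliferative activity, read by MTT assay, with a stated time of 72 h (a higher number here means a weaker inhibitor, a lower number a stronger inhibitor), reads "not determined" (no result reported). Within the data shown here, compound 2 `O=C1O/C(=C\Cn2cnc3ncc(Br)c-3c2)C(OCc2ccccc2)=C1OCc1ccccc1` is the only member with a number: in this assay compound 2 gives 15000 nM, so it stands as the sole reference point, with one further entry lacking a value. Compound 3 `O=C1O/C(=C\Cn2cnc3cncc(Br)c32)C(OCc2ccccc2)=C1OCc1ccccc1` has not been measured. Compound 3 differs from compound 2 only in the arrangement of the bicyclic group on a saturated chain carbon bound to a double-bonded chain carbon (a group of 10 heavy atoms (6 carbon, 3 nitrogen, 1 bromine; one five-membered aromatic ring with 2 hetero atoms, one six-membered aromatic ring with 1 hetero atom) in place of a group of 10 heavy atoms (6 carbon, 3 nitrogen, 1 bromine; one five-membered aromatic ring with 1 hetero atom, one six-membered aromatic ring with 2 hetero atoms), on a saturated chain carbon bound to a double-bonded chain carbon). Among the measured compounds shown here, since no step between measured compounds is available, the expected change from compound 2 to compound 3 is small, no larger than the scatter, in no firm direction no change at the digits printed from compound 2 to compound 3 (within the scatter). On that basis compound 3 is expected to give about 15000 nM in this assay, within a range from 4000 nM to 60000 nM.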

Compound 3, half-maximal inhibitory concentration: 6800 nM
Compound 3: middle estimate off by 2.2-fold (0.34 log units), on the high side; measured number inside the range.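

On a saturated chain carbon bound to a double-bonded chain carbon, a group with one five-membered aromatic ring with 2 hetero atoms and one six-membered aromatic ring with 1 hetero atom replaces one with one five-membered aromatic ring with 1 hetero atom and one six-membered aromatic ring with 2 hetero atoms. The atoms stay the same, yet this assay shows a 2.2-fold lower number from compound 2 to compound 3 (0.34 log units; beyond the scatter). This gives the first sign that the way these atoms are joined at this position alone can shift the read-out, though only modestly, and no measurement at hand accounts for the step.

The compounds shown leave open how the number would respond if an amine or a chlorine took the place of the bromine. They also do not tell what a longer chain carrying the bicyclic group would do, or free hydroxyl groups in place of the benzyl ethers on the shared core.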